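Naphthalene to iodophenyl on the amide carbonyl

The source may report more compounds than this note shows. Statements on the series, on what has been measured and on what is new or still open speak of the compounds shown alone.

Measured compounds:
compound 1, `COC(=O)c1scc(-c2ccc(NC(=O)c3cc(I)ccc3F)cc2)c1OC` — "not determined" (no result reported)
compound 2, `COC(=O)c1scc(-c2ccc(NC(=O)c3ccc4ccccc4c3)cc2)c1OC` — 19500 nM

For the measured compounds named here, compound 2 carries the sole measured number in this set. In a functional assay on HepG2 cells (Homo sapiens) for antiproliferative activity, read by MTT assay, with a stated time of 24 h (on this read-out lower numbers stand for stronger inhibition and higher numbers for weaker inhibition), compound 2 gives 19500 nM, a weak effect. Going by the values given here, compound 1 returned no result in this assay, so it offers no point of comparison, and no step between two measured compounds exists.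

Compound 3, `COC(=O)c1scc(-c2ccc(NC(=O)c3cccc(I)c3)cc2)c1OC`, is the next entry. Relative to compound 2 the change is 3-iodophenyl in place of naphthalen-2-yl on a carbonyl carbon. The remaining part of the molecule, the shared core and the amide, is untouched.

Among the compounds with values here, with a single value and no measured step, the expectation for compound 3 can only be anchored on compound 2. The change from compound 2 to compound 3 is expected to move this assay at most modestly, a 1.3-fold higher number from compound 2 to compound 3 (0.11 log units; within the scatter), in the direction of a slightly weaker or unchanged effect. Compound 3 is therefore estimated at 25000 nM, with a range from 8000 nM to 80000 nM.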

Compound 3, half-maximal inhibitory concentration: 16500 nM
Estimate against measurement, compound 3: 1.5-fold (0.18 log units) above; low and high end bracket the measured number.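

For the compounds shown here, the first measured step at this position, a 1.2-fold lower number from compound 2 to compound 3 (0.07 log units; within the scatter), in this assay, shows that 3-iodophenyl and naphthalen-2-yl on this carbonyl carbon cannot be told apart on this read-out. The exchange takes out two six-membered aromatic rings of carbon only and puts in one such ring bearing iodine, yet the number stays within the scatter and both compounds remain in the same weak range. No measurement on hand offers an explanation for this outcome.

Open, as far as these compounds go, is whether a plain phenyl at this place would read like compound 3, which would say whether the iodine matters at all. Also open, from the compounds shown here alone, is whether a group of another kind on the carbonyl carbon, such as an aminomethyl or a carboxylic acid-bearing phenyl, would move the number beyond the scatter.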